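Taking One Methoxy Group Off Compound 2

The source may hold more compounds than are shown below. What is called first, only, known or untested is meant among the compounds shown, and "the series" means these compounds.

In a functional assay on M21 cells (Homo sapiens) for antiproliferative activity, read by sulforhodamine B assay, with a stated time of 48 h (a lower number here means a stronger inhibitor, a higher number a weaker inhibitor), compound 1 `O=C1NCCN1c1ccc(S(=O)(=O)Nc2cccc(Cl)c2)cc1` gives 25 nM. Compound 2 `COc1cc(NS(=O)(=O)c2ccc(N3CCNC3=O)cc2)cc(OC)c1` gives 60 nM, the higher of the two numbers, which makes it the weaker inhibitor of the pair by a gap beyond the usual scatter of repeat measurements. Compound 3 `COc1cccc(NS(=O)(=O)c2ccc(N3CCNC3=O)cc2)c1` has not yet been measured. It differs from compound 2 by one change, hydrogen in place of methoxy on an aromatic carbon. Going by the values given here, no measured pair shows this single change, so the data offer no direct guide to its size. In this assay, a small shift toward a higher number is expected, probably not beyond the scatter. The expected change is a 1.5-fold higher number from compound 2 to compound 3 (0.18 log units; within the scatter). The estimate for compound 3 is 90 nM, with an expected range of 30 nM to 270 nM.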

Compound 3, half-maximal inhibitory concentration: 65 nM
Compound 3: middle estimate off by 1.4-fold (0.14 log units), on the high side; the measured number falls inside the stated range.
By their numbers in this assay, from the lowest: compound 1; then compounds 2 and 3 (each within the scatter of the next).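

In this assay, taking away one methoxy group gives a 1.1-fold higher number from compound 2 to compound 3 (0.03 log units; within the scatter), so compound 2 and compound 3 cannot be told apart, and this position tolerates hydrogen in place of methoxy with no visible cost. The group on the other side of the ring still matters, however: methoxy in place of chloro on an aromatic carbon gives a 2.6-fold higher number from compound 1 to compound 3 (0.41 log units; beyond the scatter), so compound 1 keeps a real lead over compound 3 even though that step is modest. No measurement on hand explains either step.

Going by these compounds, what stays open is how other groups would behave on this aromatic carbon, such as an amine, a carboxylic acid or a longer chain. Compound 2 and compound 3 also leave unknown whether hydrogen in place of chloro, with no methoxy group on the ring at all, would hold the number.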